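The compounds below may be only part of what the source reports. "The series", "measured", "known", "first", "only" and "open" are said of these compounds alone.

Of the compounds shown here, three have been tested in a functional assay on K562 cells (Homo sapiens) for antiproliferative activity, read by MTT assay, with a stated time of 48 h; on this read-out lower numbers stand for stronger inhibition and higher numbers for weaker inhibition. Among the compounds with values here, compound 1 `Oc1ccc2cc1Oc1ccc(cc1)CCc1ccc(CN3CCCC3)c(O)c1-c1ccc(cc1O)CC2` gives 4820 nM, the only actual number among the three. Compound 2 `CC(C)(C)OC(=O)N1CCN(Cc2ccc3c(c2O)-c2ccc(cc2O)CCc2ccc(O)c(c2)Oc2ccc(cc2)CC3)CC1` is recorded at > 20000 nM, which is a limit of the assay. Compound 3 `Nc1cc2cc(c1O)Oc1ccc(cc1)CCc1cccc(O)c1-c1ccc(cc1O)CC2` is recorded at > 20000 nM, and this too is a limit and not a number.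

Compound 4 `CC(=O)Nc1cc2cc(c1O)Oc1ccc(cc1)CCc1cccc(O)c1-c1ccc(cc1O)CC2` comes from compound 3 by placing acetyl in place of hydrogen on a nitrogen on an aromatic ring, which turns amino into acetamido: acetyl in place of hydrogen on a nitrogen on an aromatic ring. Within the data shown here, no measured pair in this small set isolates such a change, so the data give no direct guide to its size. In this assay no step beyond the scatter is expected, and no direction can be favoured. The expected step is a number no higher from compound 3 to compound 4 (the limit leaves the size open). This expectation rests on compound 3, whose value of > 20000 nM is a limit. For compound 4 the estimate is 20000 nM, with an expected range from 9000 nM to 40000 nM, and a report of only a limit is expected to be somewhat more likely than a number.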

Compound 4, half-maximal inhibitory concentration: > 20000 nM
Compound 4 was reported as a limit; the forecaster's own chance of this, stated with the estimate: 60%; the middle value lies on the limit itself.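

Compound 3 and compound 4 are both reported only as limits and not as numbers, so no step between them can be read: the limit of > 20000 nM in this assay, at which 3 of the 4 values shown sit.

The compounds shown leave open whether acetyl in place of hydrogen on a nitrogen on an aromatic ring shifts the read-out at all, and in which direction.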